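Replacing the tolyl group on a sulfonamide nitrogen

The source may report more compounds than this note shows. Statements on the series, on what has been measured and on what is new or still open speak of the compounds shown alone.

Compound 1 `CCN(CC)C(=O)CN(c1ccc(C)cc1)S(=O)(=O)c1ccc(OC)c(OC)c1` carries a 4-methylphenyl on its sulfonamide nitrogen and a diethyl amide. In a functional assay on CHO cells for inhibition of Orexin/Hypocretin receptor type 1 (Homo sapiens), read by FLIPR and calcium flux (on this read-out higher numbers stand for weaker inhibition and lower numbers for stronger inhibition), compound 1 gives only a limit, > 10000 nM, and no number. Compound 3 `CCN(CC)C(=O)CN(c1ccc(C)cc1)S(=O)(=O)c1ccc(OC)cc1`, which differs by a hydrogen in place of methoxy on an aromatic carbon, likewise gives only a limit, > 10000 nM. The step that the two limits leave unreadable from compound 1 to compound 3 therefore cannot be read, since both values sit at the limit of > 10000 nM in this assay, at which 2 of the 3 values shown sit. Compound 2 `CCN(C(=O)CN(c1cc(N(C)C)ccc1Cl)S(=O)(=O)c1ccc(OC)c(OC)c1)c1cccc(C)n1` differs from compound 1 at several positions. In this assay compound 2 gives 17 nM. Compound 4 `CCN(CC)C(=O)CN(c1cccc(N(C)C)c1C#N)S(=O)(=O)c1ccc(OC)c(OC)c1` arises from compound 1 by 2-cyano-3-(dimethylamino)phenyl in place of 4-methylphenyl on a sulfonamide nitrogen. Among the compounds with values here, no measured step isolates this change, and the single measured step is unreadable. Compound 2 shows that an aryl group bearing dimethylamino, together with a different amide, can reach 17 nM. Compound 1 stands only at a limit, and the size of the step is open. Compound 4 is expected to give 3000 nM (between 400 nM and 20000 nM). That would mean an expected step of an at least 3.3-fold lower number from compound 1 to compound 4 (0.52 log units; beyond the scatter) toward stronger inhibition.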

Compound 4, half-maximal inhibitory concentration: > 10000 nM
Compound 4: a limit, no number; the forecaster's own chance of this, stated with the estimate: 35%; middle value at least 3.3-fold (0.52 log units) from the limit.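

In this assay compound 4, like compound 1, gives only a limit, so no step between them can be read: the limit of > 10000 nM in this assay, at which 3 of the 4 values shown sit.

The compounds shown leave open which of the differences between compound 1 and compound 2 goes with the value of compound 2, 17 nM.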